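A few compounds are considered here, and "the series" means these few. Any claim that something is new, unique, unknown or untested is made for them only; others in the source may bear on it.

Compound 1, with the structure `CS/C(=N\C(=O)c1ccno1)NC(=O)c1ccno1`, and compound 2, with the structure `O=C(/N=C(/NC(=O)c1ccno1)[Se]Cc1ccccc1)c1ccno1`, share a core and differ in one group. In a functional assay on HepG2 cells (Homo sapiens) for cytotoxicity, read by MTT assay, with a stated time of 72 h (on this read-out lower numbers stand for higher toxicity in this test and higher numbers for lower toxicity in this test), compound 1 reaches only the limit of the assay, > 100000 nM, and no number. In this assay compound 2 also stops at the limit, > 100000 nM. The change between them is a group of 2 heavy atoms (1 carbon, 1 sulfur; no ring) in place of a group of 8 heavy atoms (7 carbon, 1 selenium; one six-membered aromatic ring of carbon only), on a carbon with a double bond to nitrogen, and the step it made is a step that the two limits leave unreadable from compound 2 to compound 1, because the limit of > 100000 nM in this assay, at which 2 of the 3 values shown sit, hides its size. Compound 3, with the structure `O=C(/N=C(/NC(=O)c1cc(-c2ccccc2)nc2ccccc12)[Se]Cc1ccccc1)c1cc(-c2ccccc2)nc2ccccc12`, carries a different core; how that core differs from the core of compound 2 is not broken down here. In this assay, for the measured compounds named here, compound 3 gives 78900 nM, the only number among the three. Compound 4, with the structure `CS/C(=N\C(=O)c1cc(-c2ccccc2)nc2ccccc12)NC(=O)c1cc(-c2ccccc2)nc2ccccc12`, is not yet measured; it is made from compound 3 by the same change, (a group of 2 heavy atoms (1 carbon, 1 sulfur; no ring) in place of a group of 8 heavy atoms (7 carbon, 1 selenium; one six-membered aromatic ring of carbon only), on a carbon with a double bond to nitrogen). Beside the earlier step, the step is expected to be a 1.3-fold higher number from compound 3 to compound 4 (0.10 log units; within the scatter), since the first pair offers no readable size to lean on. Compound 4 is expected to give about 100000 nM, most likely between 40000 nM and 250000 nM.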

Compound 4, concentration lethal to 50% of the cells: > 100000 nM
Compound 4: only a limit was reported; the forecaster's own chance of this, stated with the estimate: 55%; the middle value lies on the limit itself.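

In this assay compound 4 gives > 100000 nM as a limit and not a number. Moving from the group of carbon and selenium with its six-membered aromatic ring to methylsulfanyl on this second core gives an at least 1.2-fold higher number from compound 3 to compound 4 (0.10 log units; that floor lies within the scatter) and, with that floor within the scatter, this shows only that the change did not bring the number down here, not how far it rose, if it rose at all. Whether the change acts alike on both cores cannot be told, because neither step can be read to a size: the limit of > 100000 nM in this assay, at which 3 of the 4 values shown sit.

The compounds shown carry only these two groups on the carbon with a double bond to nitrogen, so what an amine or a longer chain such as hexylsulfanyl would do at that place remains open. Also open, from the compounds shown here alone, is the true toxicity of the compounds that stop at the limit, and so how far any of them really lies from compound 3.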